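The source may report more compounds than this note shows. Statements on the series, on what has been measured and on what is new or still open speak of the compounds shown alone.

Working notes on the series. Compound 1 `CN(C(=O)NC(=O)c1ccc(F)c(F)c1)c1nc(C(F)(F)F)c(C(=O)N/N=C/c2ccc(C(F)(F)F)cc2)s1`, compound 2 `CN(C(=O)NC(=O)c1ccc(F)c(F)c1)c1nc(C(F)(F)F)c(C(=O)N/N=C/c2ccccc2C(F)(F)F)s1` and compound 3 `CN(C(=O)NC(=O)c1ccc(F)c(F)c1)c1nc(C(F)(F)F)c(C(=O)N/N=C/c2cccc(C(F)(F)F)c2)s1` share one core and differ only in the trifluoromethylphenyl on the carbon with a double bond to nitrogen. In a functional assay on MCF7 cells (Homo sapiens) for inhibition, read by MTT assay, with a stated time of 72 h (a lower number here means a stronger inhibitor, a higher number a weaker inhibitor), compound 1 gives 5.93 ug/mL, compound 2 gives 8.21 ug/mL and compound 3 gives 4.15 ug/mL. The steps of a 1.4-fold higher number from compound 1 to compound 2 (0.14 log units; within the scatter), a 1.4-fold lower number from compound 1 to compound 3 (0.16 log units; within the scatter) and a 2.0-fold lower number from compound 2 to compound 3 (0.30 log units; within the scatter) all lie within the scatter, so although compound 2 carries the highest of the three numbers, it is not separated from the others. Compound 4 `CN(C(=O)NC(=O)c1c(F)cccc1F)c1nc(C(F)(F)F)c(C(=O)N/N=C/c2ccccc2C(F)(F)F)s1` departs from compound 2 at another place: 2,6-difluorophenyl in place of 3,4-difluorophenyl on a carbonyl carbon. Going by the values given here, no measured step touches the difluorophenyl on the carbonyl carbon, so nothing bears directly on this change. Compound 4 is therefore expected near 8.2 ug/mL, range 4 ug/mL to 17 ug/mL, with the step of a 1.0-fold lower number from compound 2 to compound 4 (0.00 log units; within the scatter) expected to stay within the scatter.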

Compound 4, half-maximal inhibitory concentration: 20.4 ug/mL
Estimate against measurement, compound 4: 2.5-fold (0.40 log units) below; the whole stated range lies below it.
By their numbers in this assay, from the lowest: compounds 3, 1 and 2 (each within the scatter of the next); then compound 4.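

Going by these compounds alone, the difluorophenyl on the carbonyl carbon gives the first step beyond the scatter: in this assay the exchange of 3,4-difluorophenyl for 2,6-difluorophenyl gives a 2.5-fold higher number from compound 2 to compound 4 (0.40 log units; beyond the scatter) with the same atoms joined differently. The fluorine arrangement on this ring therefore matters modestly here, unlike the trifluoromethylphenyl exchanges among compound 1, compound 2 and compound 3. Nothing available explains the step.

Going by these compounds, whether this loss carries over to the other trifluoromethylphenyl groups remains open. So does the outcome of an amine or a carboxylic acid on this ring.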